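A few compounds are considered here, and "the series" means these few. Any claim that something is new, unique, unknown or untested is made for them only; others in the source may bear on it.

In an in vitro ADME assay on microsomes from liver (Homo sapiens) for pharmacokinetics (a higher number here means faster removal of the compound, a lower number slower removal), compound 1 `Cc1ccc(S(=O)(=O)N2C=CNC(=O)[C@H]2CC(=O)N[C@H]2CCN(CC(C)C)CC2(C)C)cc1` gives 27 mL.min-1.g-1 and compound 2 `Cc1ccc(S(=O)(=O)N2C=CNC(=O)[C@H]2CC(=O)N[C@H]2CCN(C3CCC3)CC2(C)C)cc1` gives 24 mL.min-1.g-1, so these two stand level within the scatter. Compound 3 `Cc1ccc(S(=O)(=O)N2C=CNC(=O)[C@H]2CC(=O)N[C@H]2CCN(C3CCCC3)CC2(C)C)cc1` differs from compound 2 at one place, (cyclopentyl in place of cyclobutyl on an amine nitrogen in a ring), with cyclopentyl in place of cyclobutyl on an amine nitrogen in a ring. Going by the values given here, the only measured step at this nitrogen is a 1.1-fold lower number from compound 1 to compound 2 (0.05 log units; within the scatter), with cyclobutyl in place of isobutyl. On that single step, no change beyond the scatter is expected in this assay. The estimated step is a 1.2-fold higher number from compound 2 to compound 3 (0.07 log units; within the scatter). Compound 3 is expected to give 28 mL.min-1.g-1, within an estimated range of 15 mL.min-1.g-1 to 50 mL.min-1.g-1.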

Compound 3, intrinsic clearance in microsomes: < 14 mL.min-1.g-1
Compound 3: a limit, no number; the forecaster's own chance of this, stated with the estimate: 3%; middle value at least 2.0-fold (0.30 log units) away from the limit.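

In this assay, going by these compounds alone, the earlier swap on this amine nitrogen changed nothing beyond the scatter, while cyclopentyl gives the first reading that reaches the limit of the assay. As far as these compounds go, the new group gives an at least 1.7-fold lower number from compound 2 to compound 3 (0.23 log units; that floor lies within the scatter) and an at least 1.9-fold lower number from compound 1 to compound 3 (0.28 log units; that floor lies within the scatter); each step is only a floor, so its full size stays unknown. For compound 3 the reading is a limit and not a number: the limit of < 14 mL.min-1.g-1 in this assay, at which 1 of the 3 values shown sits.

Open, from the compounds shown here alone, is how a cyclohexyl or a tetrahydropyranyl group on this nitrogen would read in this assay. Also open, going by these compounds, is whether cyclopentyl would give the same result on a different core.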